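The source may hold more compounds than are shown below. What is called first, only, known or untested is meant among the compounds shown, and "the series" means these compounds.

Compound 1, `COc1cc(/C=N/NC(=O)c2cnccn2)ccc1O`, gives 34.7% in a functional assay on the whole organism (strain Swiss) for inhibition, with Mus musculus as the target, with stated times of 40 min and 6 h, at a dose of 100 mg/kg by the oral route; a lower number here means less inhibition, a higher number more inhibition at the dose given (going by the name of the read-out).
Compound 2, `O=C(N/N=C/c1ccc(-c2ccccc2)cc1)c1cnccn1`, gives 14.4% in this assay.
Compound 3, `O=C(N/N=C/c1ccc(O)cc1)c1cnccn1`, gives 43.1% in this assay.

Among these three numbers compound 3 has the highest. Its nearest neighbour is compound 1, with a number 8.4 percentage points higher from compound 1 to compound 3 (within the scatter), a gap that sits within the scatter, so the two cannot be told apart. Its furthest neighbour is compound 2, with a number 28.7 percentage points higher from compound 2 to compound 3 (beyond the scatter), a gap that lies beyond the scatter.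

Compound 4, `O=C(N/N=C/c1ccccc1)c1cnccn1`, differs from compound 3 in one place: hydrogen in place of hydroxy on an aromatic carbon. Among the compounds with values here, two measured steps bear on this. The step from compound 1 to compound 3 removed a group from the same carbon and stayed within the scatter. The step from compound 2 to compound 3 brought the hydroxy in and was modest but beyond the scatter. Taking the hydroxy away again is therefore expected to lower the number in this assay by a modest amount, though the within-scatter step from compound 1 to compound 3 leaves room for no change at all.

Compound 4 is accordingly expected to give about 30% in this assay, with a range from 15% to 45%, which corresponds to an expected step of a number 13.1 percentage points lower from compound 3 to compound 4 (beyond the scatter).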

Compound 4, a percentage reported as inhibition, in the whole organism at one dose (the size of the read-out at that dose, not a potency): 21.7%
The estimate for compound 4 lay 8.3 percentage points above the measured number; the measured number falls inside the stated range.
By their numbers in this assay, from the lowest: compounds 2 and 4 (each within the scatter of the next); then compounds 1 and 3 (each within the scatter of the next).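

In this assay, within the data shown here, the exchange of hydroxy for hydrogen on this aromatic carbon, para to a large group, gives a number 21.4 percentage points lower from compound 3 to compound 4 (beyond the scatter) and is the first step that measures the hydroxy against a bare ring position with nothing else changing. The exchange of phenyl for hydrogen at the same place gives a number 7.3 percentage points higher from compound 2 to compound 4 (within the scatter) and the two compounds cannot be told apart, so the loss of the phenyl alone does not account for the earlier gap between compound 2 and compound 3, and the presence of the hydroxy does. Nothing available here offers a reason why the hydroxy matters at this place.

The compounds shown leave open whether an amine or a carboxylic acid on this carbon would hold the number near that of compound 3 at 43.1% or would fall back toward that of compound 4 at 21.7% in this read-out. They also leave open what a methoxy alone on this carbon would give, as the only methoxy shown, in compound 1, stands on the ring together with the hydroxy.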